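Methyl on the benzyl ring of compound 3

This account rests on a few compounds, and the source may have more. Where it says the series, first, only, none or still open, it means among the compounds named here.

Three compounds of the series have a number in a functional assay on HT-29 cells (Homo sapiens) for cytotoxicity, read by MTT assay, with a stated time of 72 h; a lower number here means a stronger inhibitor, a higher number a weaker inhibitor. Compound 1 `CN(C)CCNc1nc(N/N=C/c2ccc(F)cc2Cl)nc2ccccc12` gives 330 nM in this assay. Compound 2 `CN(C)CCCNc1nc(N/N=C/c2ccc(Cl)cc2)nc2ccccc12` gives 270 nM in this assay. Compound 3 `CN(C)CCNc1nc(N/N=C/c2nccn2Cc2ccccc2)nc2ccccc12` gives 2620 nM in this assay, the highest of the three numbers; the gaps to compound 1 and to compound 2 both lie beyond the scatter, so compound 3 is the weakest inhibitor among them.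

Compound 4 `Cc1ccc(Cn2ccnc2/C=N/Nc2nc(NCCN(C)C)c3ccccc3n2)cc1` has not been measured in this assay. It differs from compound 3 in one place: methyl in place of hydrogen on an aromatic carbon of the six-membered aromatic ring of carbon only, para to a large group; read one bond further out, benzyl becomes 4-methylbenzyl. Among the measured compounds shown here, no pair within the measured set shows this change, so its effect is unknown here. A single added methyl at such a position is expected to shift the number little, likely no further than the scatter, in either direction; the step from compound 3 to compound 4 is estimated as a 1.1-fold lower number from compound 3 to compound 4 (0.06 log units; within the scatter). For compound 4 the expected value in this assay is 2300 nM, with a range from 900 nM to 6000 nM.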

Compound 4, half-maximal inhibitory concentration: 1410 nM
Estimate against measurement, compound 4: 1.6-fold (0.21 log units) above; measured number inside the range.
By their numbers in this assay, from the lowest: compounds 2 and 1 (each within the scatter of the next); then compounds 4 and 3 (each within the scatter of the next).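

In this assay, among the compounds shown here, the first pair of the series that differs in one place gives a 1.9-fold lower number from compound 3 to compound 4 (0.27 log units; within the scatter), for methyl in place of hydrogen on an aromatic carbon of the six-membered aromatic ring of carbon only, para to a large group. At this position, then, benzyl and 4-methylbenzyl are not told apart, and this single pair is all that supports that reading. No accompanying measurement bears on this result.

Open, from the compounds shown here alone, is whether the position admits groups other than methyl, such as a chlorine atom, a methoxy group, an amine or a carboxylic acid. Also open, going by these compounds, is whether the same change reads alike on the other carbons of that ring, or with a longer chain in place of the dimethylaminoethyl chain of compound 4.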